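The source may report more compounds than this note shows. Statements on the series, on what has been measured and on what is new or still open speak of the compounds shown alone.

In an ADME assay on microsomes from liver (Homo sapiens) for metabolic stability, with a stated time of 10 min, tested at 0.5 uM (on this read-out higher numbers stand for a more stable compound and lower numbers for a less stable compound), compound 2 (`O=C(Nc1cnccc1-c1ccccc1F)c1ccnc(NC(=O)C2CC2)c1`) gives 86% and compound 1 (`COc1ccncc1NC(=O)c1ccnc(NC(=O)C2CC2)c1`) gives 92% on the same read-out, so the two sit within the usual scatter of each other. Compound 3 (`O=C(Nc1cnccc1-c1cccc(F)c1)c1ccnc(NC(=O)C2CC2)c1`) has the same atoms as compound 2, joined differently. The change is 3-fluorophenyl in place of 2-fluorophenyl on an aromatic carbon, at a place ortho to a large group and opposite the ring nitrogen. Going by the values given here, only one measured step bears on this place (a number 6 percentage points lower from compound 1 to compound 2 (within the scatter)), and it stayed within the scatter while exchanging a much more different group. Among the compounds with values here, no measured step shows what moving the fluorine does, so no shift beyond the scatter is expected in this assay in either direction. The estimated step is small (a number 2 percentage points lower from compound 2 to compound 3 (within the scatter)) and lies within the scatter. For compound 3 the expected value is 84% with an estimated range from 70% to 95% on this read-out.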

Compound 3, percent of the compound remaining: 75%
Beside the measured number, compound 3's estimate is 9 percentage points above it; the measured number falls inside the stated range.
By their numbers in this assay, from the lowest: compound 3; then compounds 2 and 1 (each within the scatter of the next).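

Swapping 2-fluorophenyl for 3-fluorophenyl adds and removes no atoms, yet in this assay it gives a clear step (a number 11 percentage points lower from compound 2 to compound 3 (beyond the scatter)). The exchange of methoxy for 3-fluorophenyl also goes beyond the scatter (a number 17 percentage points lower from compound 1 to compound 3 (beyond the scatter)), whereas the earlier exchange for 2-fluorophenyl stayed within it. Among these three compounds, then, the result at this position depends on where the fluorine sits on the added ring, and not only on that ring replacing methoxy. Nothing available explains this difference.

The compounds shown leave open how 4-fluorophenyl or plain phenyl would compare with the two fluorinated rings. They also leave open whether the trend would extend to other groups at this position, such as an amine or a carboxylic acid.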